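A few compounds are considered here, and "the series" means these few. Any claim that something is new, unique, unknown or untested is made for them only; others in the source may bear on it.

Going by the values given here, in a functional assay on A2780 cells (Homo sapiens) for antiproliferative activity, read by fluorescence, with a stated time of 72 h (on this read-out lower numbers stand for stronger inhibition and higher numbers for weaker inhibition), three compounds on the shared core have numbers so far: compound 1 `CN1CCC(C(=O)N2Cc3c(NC(=O)C4CC4)n[nH]c3C2(C)C)CC1` gives 1420 nM, compound 2 `CN1CCC(C(=O)N2Cc3c(NC(=O)NCc4ccccc4)n[nH]c3C2(C)C)CC1` gives 2680 nM and compound 3 `CN1CCC(C(=O)N2Cc3c(NC(=O)Nc4cccc(F)c4)n[nH]c3C2(C)C)CC1` gives 350 nM. Compound 3 has the lowest of the three numbers.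

Compound 4 `CN1CCC(C(=O)N2Cc3c(NC(=O)c4ccncc4)n[nH]c3C2(C)C)CC1` differs from compound 3 as follows: pyridin-4-yl in place of (3-fluorophenyl)amino on a carbonyl carbon. In words, pyridin-4-yl stands in place of (3-fluorophenyl)amino on a carbonyl carbon.

Among the compounds with values here, three measured steps bear on this change. Replacing cyclopropyl at the same place gives a 4.1-fold lower number from compound 1 to compound 3 (0.61 log units; beyond the scatter) and a 1.9-fold higher number from compound 1 to compound 2 (0.28 log units; within the scatter), while the change from benzyl to 3-fluorophenyl gives a 7.7-fold lower number from compound 2 to compound 3 (0.88 log units; beyond the scatter). Within the data shown here, no measured compound carries an aromatic ring directly on that carbonyl, so the evidence is indirect and the range must stay wide. Compound 3 loses the group that gave a 4.1-fold lower number from compound 1 to compound 3 (0.61 log units; beyond the scatter), so part of that gain may be lost too. The step expected in this assay is modest and towards a higher number, namely a 2.0-fold higher number from compound 3 to compound 4 (0.30 log units; within the scatter). The estimate for compound 4 is 700 nM, with an expected range from 200 nM to 2200 nM.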

Compound 4, half-maximal inhibitory concentration: 500 nM
Beside the measured number, compound 4's estimate is 1.4-fold (0.15 log units) above it; measured number inside the range.
By their numbers in this assay, from the lowest: compounds 3 and 4 (each within the scatter of the next); then compounds 1 and 2 (each within the scatter of the next).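

In this assay, a ring set directly on the carbonyl carbon serves as well as one reached through an amide-type nitrogen, with a 1.4-fold higher number from compound 3 to compound 4 (0.15 log units; within the scatter) as the step, so (3-fluorophenyl)amino is not needed for a number at this level. Pyridin-4-yl also separates from both other groups, with a 2.8-fold lower number from compound 1 to compound 4 (0.45 log units; beyond the scatter) and a 5.4-fold lower number from compound 2 to compound 4 (0.73 log units; beyond the scatter) as its steps, but an aromatic ring alone does not account for the level, and compound 2, which carries a phenyl ring in its benzylamino group, goes against that reading. No measurement on these compounds speaks to the cause of these steps.

Going by these compounds, what a plain phenyl or a pyridin-3-yl on that carbonyl would give remains open, which leaves the role of the ring nitrogen undecided. Also open, on these data alone, is how a 3-fluorophenyl directly on the carbonyl compares with (3-fluorophenyl)amino at this position.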